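The compounds below may be only part of what the source reports. "The series", "measured", "known", "first", "only" and "open" are said of these compounds alone.

Measured so far:
- compound 1 `COc1cc(C=O)cc2c1CC(C)(C)O2`: 1100000 nM
- compound 2 `COc1cc(C(=O)O)cc2c1CC(C)(C)O2`: > 1350000 nM, a limit
- compound 3 `CC1(C)Cc2c(Oc3ccccc3)cc(C(=O)O)cc2O1`: > 1050000 nM, a limit

In a functional assay on the whole organism with Homo sapiens as the target, read by hemolysis (on this read-out higher numbers stand for weaker inhibition and lower numbers for stronger inhibition), compound 1 gives 1100000 nM. For compound 2 the assay reports only a limit, > 1350000 nM. For compound 3 the assay likewise reports only a limit, > 1050000 nM. Compound 2 thus sits at a limit rather than at a number (the limit of > 1350000 nM in this assay, at which 1 of the 3 values shown sits), and the step into it cannot be sized beyond its floor: an at least 1.2-fold higher number from compound 1 to compound 2 (0.08 log units; that floor lies within the scatter). The other measured step leads away from compound 2 and is also unreadable: a step that the two limits leave unreadable from compound 2 to compound 3.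

Compound 4 `COc1cc(-c2nn[nH]n2)cc2c1CC(C)(C)O2` is not yet measured. It differs from compound 2 by 2H-tetrazol-5-yl in place of carboxy on an aromatic carbon. Within the data shown here, neither measured step involves an exchange of the carboxy group for a ring, and neither gives a readable size, so no measured step bears directly on this change. Compound 4 is therefore expected to show no step beyond the scatter in this assay, a step that the limit leaves unreadable from compound 2 to compound 4, and most likely to return again only a limit. The estimate for compound 4 in this assay is 1500000 nM, with a range from 600000 nM to 4000000 nM.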

Compound 4, half-maximal inhibitory concentration: 245000 nM
For compound 4 the middle estimate is 6.1-fold (0.79 log units) above the measured one, and the stated range ends above it.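

In this assay, among these compounds, the aromatic carbon para to a fused ring now proves sensitive to the group it carries: 2H-tetrazol-5-yl in place of carboxy gives an at least 5.5-fold lower number from compound 2 to compound 4 (0.74 log units; beyond the scatter), a step beyond the scatter of a kind the earlier compounds did not provide. Against formyl at the same carbon, the same ring gives a 4.5-fold lower number from compound 1 to compound 4 (0.65 log units; beyond the scatter), so the lower number of compound 4 also holds against a measured value and not only against a floor. The step from the carboxy compound can be sized only as a floor, because compound 2 is held at a limit: the limit of > 1350000 nM in this assay, at which 1 of the 4 values shown sits.

From the compounds shown here alone, compound 3 also remains at a limit, its step from compound 2 cannot be read, and the effect of phenyl on that oxygen therefore stays open. Also open, going by these compounds, is whether the lower number belongs to the tetrazole ring specifically or would extend to other groups at this aromatic carbon, such as an oxadiazole ring, a sulfonamide or an amine.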